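Same Change, Second Core: Expected Result for Compound 4

The compounds below may be only part of what the source reports. "The series", "measured", "known", "first", "only" and "open" are said of these compounds alone.

Compound 1 `O=C1[C@@H](NS(=O)(=O)c2ccc(-c3ccncc3)s2)CCN1Cc1cc2[nH]cccc-2n1` is measured in an assay on isolated protein for inhibition of coagulation factor X (Oryctolagus cuniculus), tested at 1 uM (a higher number here means more inhibition at the concentration tested (going by the name of the read-out), a lower number less inhibition), where compound 1 gives 35%. Compound 2 `O=C1[C@@H](NS(=O)(=O)c2ccc(-c3ccncc3)s2)CCN1Cc1cc2c[nH]ccc-2n1` carries a group of 9 heavy atoms (7 carbon, 2 nitrogen; one five-membered aromatic ring with 1 hetero atom, one six-membered aromatic ring with 1 hetero atom) in place of a group of 9 heavy atoms (7 carbon, 2 nitrogen; one five-membered aromatic ring with 1 hetero atom, one six-membered aromatic ring with 1 hetero atom), on a saturated chain carbon bound to an amide-type nitrogen in a ring; in this assay compound 2 gives 21%, a change of a number 14 percentage points lower from compound 1 to compound 2 (beyond the scatter). Compound 3 `O=C1[C@@H](NS(=O)(=O)c2cc3cccnc3s2)CCN1Cc1cc2[nH]cccc-2n1` has a different core; the difference between the two cores is not broken down here. In this assay compound 3 gives 44%, and this value and that of compound 1 lie within the scatter of each other. Compound 4 `O=C1[C@@H](NS(=O)(=O)c2cc3cccnc3s2)CCN1Cc1cc2c[nH]ccc-2n1` has not been measured and differs from compound 3 by a group of 9 heavy atoms (7 carbon, 2 nitrogen; one five-membered aromatic ring with 1 hetero atom, one six-membered aromatic ring with 1 hetero atom) in place of a group of 9 heavy atoms (7 carbon, 2 nitrogen; one five-membered aromatic ring with 1 hetero atom, one six-membered aromatic ring with 1 hetero atom), on a saturated chain carbon bound to an amide-type nitrogen in a ring, the same change as from compound 1 to compound 2. For compound 4 the expected step is a number 14 percentage points lower from compound 3 to compound 4 (beyond the scatter), set beside the measured a number 14 percentage points lower from compound 1 to compound 2 (beyond the scatter); this expectation rests on that single earlier example alone. Compound 4 is therefore estimated at 30%, most likely between 15% and 45%.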

Compound 4, a percentage reported as inhibition, at one concentration (the size of the read-out at that concentration, not a potency): 18%
The estimate for compound 4 lay 12 percentage points above the measured number; measured number inside the range.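

On the second core, the change again lowers the number in this assay, giving a number 26 percentage points lower from compound 3 to compound 4 (beyond the scatter). Both steps go the same way, and their sizes cannot be told apart: the same change on two cores in this assay, a number 14 percentage points lower (beyond the scatter) from compound 1 to compound 2 and a number 26 percentage points lower (beyond the scatter) from compound 3 to compound 4, 12 percentage points apart, within the scatter of two such steps. This shows that the drop carries over between these two cores, but two pairs are a small base, and they show neither that it would hold on any other core nor why it occurs.

On these data alone, it remains open whether the same drop would appear if a further group, such as an amine or a carboxylic acid, were attached to either core. As far as these compounds go, how the two pairs would compare at other test concentrations also remains open.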